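Swapping Vinyl for (2,3-dihydroxypropyl)carbamoyl on the Side Chain

This account rests on a few compounds, and the source may have more. Where it says the series, first, only, none or still open, it means among the compounds named here.

In a functional assay on HCT-116 cells (Homo sapiens) for antiproliferative activity, read by sulforhodamine B assay, with a stated time of 72 h (a lower number here means a stronger inhibitor, a higher number a weaker inhibitor), compound 1 (`CNC(=O)C[C@@H]1C[C@@H](c2ccc(Cl)c(Cl)c2)[C@H](NC(=O)c2cc(-c3c(Cl)cnn3C)c(Cl)o2)CN1`) gives 450 nM. Among the compounds with values here, compound 2 (`C=CC[C@@H]1C[C@@H](c2ccc(Cl)c(Cl)c2)[C@H](NC(=O)c2cc(-c3c(Cl)cnn3C)c(Cl)o2)CN1`) gives 780 nM in this assay, which lies within the scatter of compound 1, the only other compound with a measured value. Compound 3 (`Cn1ncc(Cl)c1-c1cc(C(=O)N[C@@H]2CN[C@H](CC(=O)NCC(O)CO)C[C@H]2c2ccc(Cl)c(Cl)c2)oc1Cl`) has not yet been measured. Its structure differs from that of compound 2 as follows: (2,3-dihydroxypropyl)carbamoyl in place of vinyl on a saturated chain carbon bound to a saturated ring carbon. In words, (2,3-dihydroxypropyl)carbamoyl stands in place of vinyl on a saturated chain carbon bound to a saturated ring carbon. Within the data shown here, the one measured step at this place is a 1.7-fold higher number from compound 1 to compound 2 (0.24 log units; within the scatter), with vinyl in place of methylcarbamoyl. Among the measured compounds shown here, compound 3 carries a carbamoyl group there again, as compound 1 does, but no measured compound shows what the 2,3-dihydroxypropyl part does. A step beyond the scatter is therefore not expected in this assay, and the number is expected to fall slightly, towards compound 1 at 450 nM. The expected change is a 1.5-fold lower number from compound 2 to compound 3 (0.18 log units; within the scatter). For compound 3 the estimate is 520 nM, with an expected range of 200 nM to 1350 nM.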

Compound 3, half-maximal inhibitory concentration: 7090 nM
Compound 3: middle estimate off by 14-fold (1.13 log units), on the low side, and the stated range ends below it.
By their numbers in this assay, from the lowest: compounds 1 and 2 (each within the scatter of the next); then compound 3.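

In this assay, the side chain on a saturated chain carbon bound to a saturated ring carbon proved sensitive to what it carries: the earlier exchange of methylcarbamoyl for vinyl stayed within the scatter, whereas (2,3-dihydroxypropyl)carbamoyl in place of vinyl gives a 9.1-fold higher number from compound 2 to compound 3 (0.96 log units; beyond the scatter) and moves beyond it. The closest comparison places 1,2-dihydroxyethyl in place of hydrogen on a saturated chain carbon bound to an amide-type nitrogen, and it gives a 16-fold higher number from compound 1 to compound 3 (1.20 log units; beyond the scatter), the largest step among these compounds. The carbamoyl group alone therefore does not account for the weaker number, as compound 1 carries it too and stays within the scatter of compound 2, so the loss goes with the added 1,2-dihydroxyethyl part.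

From the compounds shown here alone, it remains open whether a single 2-hydroxyethyl group, a methoxyethyl group, an amine or a carboxylic acid at that same amide-type nitrogen would give a loss of similar size, or whether a plain longer alkyl chain would. Nothing available here bears on the reason for the loss.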